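This account rests on a few compounds, and the source may have more. Where it says the series, first, only, none or still open, it means among the compounds named here.

Working notes on the series, cytotoxicity arm. The read-out throughout is a toxicity assay on HepG2 cells (Homo sapiens) for inhibition, read by CellTiter-Glo, with a stated time of 48 h; on this read-out lower numbers stand for stronger inhibition and higher numbers for weaker inhibition. Compound 1 `Cc1cc(C)cc(NC(=O)COc2cc(C)nc3ccc(Cl)cc23)c1` returns only a limit in this assay, > 100000 nM. Compound 2 `COc1ccc(NC(=O)COc2cc(C)nc3ccc(OC)cc23)cc1` likewise returns only a limit in this assay, > 100000 nM. So compound 2 stands at the ceiling of what has been measured: every value shown for the series is a limit rather than a number, and the one feature to note is the limit of > 100000 nM in this assay, at which 2 of the 2 values shown sit. Among the measured compounds shown here, no pair of measured compounds differs in a single place, so no measured step in this assay is available to lean on.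

The next entry is compound 3 `COc1ccc2nc(C)cc(OCC(=O)Nc3ccccn3)c2c1`, not yet measured in this assay. Relative to compound 2 the change is pyridin-2-yl in place of 4-methoxyphenyl on an amide-type nitrogen.

With both measured values sitting at the limit, no step beyond the usual scatter of this assay is expected in either direction. The step from compound 2 to compound 3 is therefore expected to be close to nil, a number no higher from compound 2 to compound 3 (the limit leaves the size open). For compound 3 the estimate in this assay is 100000 nM, with a range from 30000 nM to 300000 nM, and most likely the assay will again report only a limit.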

Compound 3, half-maximal inhibitory concentration: > 100000 nM
Compound 3: only a limit was reported; the forecaster's own chance of this, stated with the estimate: 85%; the middle value lies on the limit itself.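

Compound 3 returns only a limit in this assay, and compound 2 does too, so no step can be read between compound 2 and compound 3. Every value shown so far is of this kind: the limit of > 100000 nM in this assay, at which 3 of the 3 values shown sit.

The compounds shown leave open whether any change on the shared core would give a readable inhibition value in this read-out.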